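Swapping a Sulfonyl for a Urea on the Piperazine

A few compounds are considered here, and "the series" means these few. Any claim that something is new, unique, unknown or untested is made for them only; others in the source may bear on it.

Of the compounds shown here, two have been measured in a functional assay on MDA-MB-436 cells (Homo sapiens) for antiproliferative activity, read by MTT assay, with a stated time of 48 h; a lower number here means a stronger inhibitor, a higher number a weaker inhibitor. Compound 1 `C=CS(=O)(=O)N1CCN(c2ncnc3sc(-c4cnn(Cc5ccccc5)c4)cc23)CC1` gives 18300 nM in this assay. Compound 2 `CN1CCN(c2ccc(-c3cc4c(N5CCN(S(=O)(=O)/C=C/c6ccccc6)CC5)ncnc4s3)cc2)CC1` carries a larger substituent on the shared core and gives 8670 nM in this assay, which is the lower of the two numbers; the gap to compound 1 lies beyond the usual scatter.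

The next compound, compound 3 `CN1CCN(c2ccc(-c3cc4c(N5CCN(C(=O)Nc6ccc(F)cc6F)CC5)ncnc4s3)cc2)CC1`, keeps the core of compound 2 and differs only in one place: (2,4-difluorophenyl)carbamoyl in place of (2-phenylethenyl)sulfonyl on an amine nitrogen in a ring. Both groups have the same count of heavy atoms and each holds one six-membered aromatic ring of carbon only, but the group that leaves has three double bonds outside aromatic rings and no hydrogen-bond donor, while the group that enters has one such double bond and one hydrogen-bond donor.

Going by the values given here, no measured pair isolates this kind of change, so the expectation rests on compound 2 alone. The step of a 1.6-fold higher number from compound 2 to compound 3 (0.21 log units; within the scatter) is expected to be modest, toward a weaker inhibitor, and may not exceed the scatter. Compound 3 is therefore estimated at 14000 nM in this assay, with a range from 3500 nM to 56000 nM.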

Compound 3, half-maximal inhibitory concentration: 20200 nM
The estimate for compound 3 lay 1.4-fold (0.16 log units) below the measured number; measured number inside the range.
By their numbers in this assay, from the lowest: compound 2; then compounds 1 and 3 (each within the scatter of the next).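

In this assay, replacing (2-phenylethenyl)sulfonyl with (2,4-difluorophenyl)carbamoyl on an amine nitrogen in a ring gives a 2.3-fold higher number from compound 2 to compound 3 (0.37 log units; beyond the scatter), the first sign that the number responds to the group at this position, here toward a weaker inhibitor. The step arises although both groups have the same count of heavy atoms and each holds one six-membered aromatic ring of carbon only, so those two shared features do not by themselves fix the number. No measurement at hand accounts for the step, and the differences that travel together in this single exchange cannot be told apart.

The compounds shown leave open whether the step follows the carbamoyl link or the two fluorine atoms, a question that a phenylcarbamoyl group without fluorine on the same nitrogen would help to settle. Also open, on these data alone, is how far this position tolerates groups with no aromatic ring, such as an acetyl or a methyl group, and whether the same exchange would give a similar step on the core of compound 1.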